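A few compounds are considered here, and "the series" means these few. Any claim that something is new, unique, unknown or untested is made for them only; others in the source may bear on it.

In a functional assay on CCRF-CEM cells (Homo sapiens) for inhibition (on this read-out higher numbers stand for weaker inhibition and lower numbers for stronger inhibition), compound 1 (`OC[C@H]1OC(n2cnc3c(-c4ccco4)ncnc32)[C@H](O)[C@@H]1O`), with furan-2-yl on the shared core, gives 600 nM as the lowest number. Compound 2 (`Cc1csc(-c2ncnc3c2ncn3C2O[C@H](CO)[C@@H](O)[C@H]2O)c1`), with 4-methylthiophen-2-yl, gives 2900 nM and compound 3 (`Cn1cccc1-c1ncnc2c1ncn2C1O[C@H](CO)[C@@H](O)[C@H]1O`), with 1-methyl-1H-pyrrol-2-yl, gives 2000 nM on the same core. Compound 3 thus stands level with compound 2 within the scatter (a 1.5-fold lower number from compound 2 to compound 3 (0.16 log units; within the scatter)) and above compound 1 beyond it (a 3.3-fold higher number from compound 1 to compound 3 (0.52 log units; beyond the scatter)), as compound 2 also does (a 4.8-fold higher number from compound 1 to compound 2 (0.68 log units; beyond the scatter)).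

The change to compound 4 (`OC[C@H]1OC(n2cnc3c(-c4cc5ccccc5o4)ncnc32)[C@H](O)[C@@H]1O`) is 1-benzofuran-2-yl in place of 1-methyl-1H-pyrrol-2-yl on an aromatic carbon and it falls on an aromatic carbon of a six-membered aromatic ring with 2 nitrogen. Going by the values given here, no measured step brings in the six-membered aromatic ring of carbon only, so the direction is poorly supported and the range is kept wide. The measured swaps stay modest, the largest being a 4.8-fold higher number from compound 1 to compound 2 (0.68 log units; beyond the scatter) in size, so no step beyond the scatter is expected in this assay as the middle case. The estimated step is a 1.5-fold higher number from compound 3 to compound 4 (0.18 log units; within the scatter) on that basis. In this assay compound 4 is estimated at 3000 nM (expected range 800 nM to 12000 nM).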

Compound 4, half-maximal inhibitory concentration: 15000 nM
For compound 4 the middle estimate is 5.0-fold (0.70 log units) below the measured one; measured number above the stated range.
By their numbers in this assay, from the lowest: compound 1; then compounds 3 and 2 (each within the scatter of the next); then compound 4.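

In this assay, 1-benzofuran-2-yl is the only group shown that adds a six-membered aromatic ring of carbon only at this aromatic carbon, and it gives the only large step so far, against furan-2-yl (a 25-fold higher number from compound 1 to compound 4 (1.40 log units; beyond the scatter)). The swaps to it from the other two groups are also beyond the scatter (a 7.5-fold higher number from compound 3 to compound 4 (0.88 log units; beyond the scatter); a 5.2-fold higher number from compound 2 to compound 4 (0.71 log units; beyond the scatter)), which makes compound 4 the weakest of the four at this position, whereas the groups with a single five-membered aromatic ring differ only modestly. Nothing available explains this loss.

From the compounds shown here alone, with a single fused group, it remains open whether the loss belongs to fused rings in general or to 1-benzofuran-2-yl alone. Going by these compounds, how an amine, a carboxylic acid or a longer alkyl chain would read at this aromatic carbon also remains open.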